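A few compounds are considered here, and "the series" means these few. Any claim that something is new, unique, unknown or untested is made for them only; others in the source may bear on it.

Working notes on the series. Compound 2 `CO[C@@H]1[C@H](N(C)c2ncc(-c3c[nH]c4ccc(Br)cc34)s2)C[C@H]2O[C@]1(C)n1c3ccccc3c3c4c(c5c6cc(Br)ccc6n2c5c31)C(=O)NC4` has been tested in an ADME assay on PBMC cells (Homo sapiens) for cytotoxicity, read by CellTiter-Glo, with a stated time of 72 h; on this read-out higher numbers stand for weaker inhibition and lower numbers for stronger inhibition; in this assay compound 2 gives > 10000 nM, which is a limit of the assay and not a measured number. Among the compounds with values here, the only other measured member is compound 1 `COc1ccc2[nH]cc(-c3cnc(N(C)[C@@H]4C[C@H]5O[C@@](C)([C@@H]4OC)n4c6ccccc6c6c7c(c8c9cc(Cl)ccc9n5c8c64)C(=O)NC7)s3)c2c1`. In this assay compound 1 likewise gives > 10000 nM, again a limit rather than a number. Compound 2 therefore stands at the limit, with no measured values against which to order it; both members sit at the limit of > 10000 nM in this assay, at which 2 of the 2 values shown sit. Within the data shown here, no step between measured compounds is available, so the direction of any change cannot be read from the data.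

Compound 3 `COc1ccc2[nH]cc(-c3cnc(N(C)[C@@H]4C[C@H]5O[C@@](C)([C@@H]4OC)n4c6ccccc6c6c7c(c8c9cc(Br)ccc9n5c8c64)C(=O)NC7)s3)c2c1` is not yet measured. It differs from compound 2 by methoxy in place of bromo on an aromatic carbon. With compound 1 and compound 2 both at the limit, compound 3 is expected to stay at or beyond the same limit, so the step from compound 2 to compound 3 is expected to be a step that the limit leaves unreadable from compound 2 to compound 3, none beyond the scatter. Compound 3 is estimated at 20000 nM in this assay, with a range from 10000 nM to 50000 nM.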

Compound 3, half-maximal inhibitory concentration: > 10000 nM
Compound 3: only a limit was reported (the forecaster's own chance of this, stated with the estimate: 85%); the middle value is on the limit's open side.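

In this assay compound 3 gives > 10000 nM, which is a limit and not a number. Within the data shown here, no step among compound 1, compound 2 and compound 3 can be read, because all three sit at the same limit: the limit of > 10000 nM in this assay, at which 3 of the 3 values shown sit. The compounds shown leave open whether bromo, chloro or methoxy changes the read-out in this assay at all.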